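The compounds below may be only part of what the source reports. "The series", "measured", "known", "first", "only" and "open" are said of these compounds alone.

In a functional assay on HepG2 cells (Mus musculus) for antiproliferative activity against HepG2 (Homo sapiens), read by MTT assay, with a stated time of 48 h (on this read-out higher numbers stand for weaker inhibition and lower numbers for stronger inhibition), compound 1 `COc1cc(/C=C/c2nnc(NC(=O)c3ccccc3Br)s2)c(Br)c(OC)c1OC` gives 250 nM. Two relatives offer a comparison: compound 2 `COc1ccc(/C=C/c2nnc(NC(=O)c3ccccc3OC)s2)cc1OC` gives 260 nM, and compound 3 `COc1ccc(/C=C/c2nnc(NC(=O)c3cc(OC)c(OC)c(OC)c3Br)s2)cc1` gives 210 nM. These three numbers lie within the usual scatter of one another, so compound 1 cannot be ranked against either relative.

Compound 4 `COc1cc(/C=C/c2nnc(NC(=O)c3ccccc3)s2)c(Br)c(OC)c1OC` keeps the core of compound 1 and changes a single place: hydrogen in place of bromo on an aromatic carbon. This puts hydrogen in place of bromo on an aromatic carbon, so that the 2-bromophenyl becomes phenyl. Within the data shown here, no measured pair here shows this change on its own, so the data give no direct size for it. Among the measured compounds shown here, the only guide is the narrow spread of the three measured compounds, which gives no sign of a large step. The expected 1.2-fold higher number from compound 1 to compound 4 (0.08 log units; within the scatter) is therefore small, with no change beyond the scatter and no firm direction. Compound 4 is estimated at 300 nM, with an expected range from 120 nM to 800 nM.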

Compound 4, half-maximal inhibitory concentration: 180 nM
Beside the measured number, compound 4's estimate is 1.7-fold (0.22 log units) above it, within the range that was stated.
By their numbers in this assay, from the lowest: compounds 4, 3, 1 and 2 (each within the scatter of the next).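

This pair gives the first direct measure of a single change at this position. In this assay, swapping bromo for hydrogen on the aromatic carbon gives a 1.4-fold lower number from compound 1 to compound 4 (0.14 log units; within the scatter), so turning the 2-bromophenyl into phenyl leaves the number unchanged within what repeated measurements can resolve, and on the core of compound 1 this bromo is not needed to keep the activity seen here. Nothing shown here bears on why the swap makes so little difference.

On these data alone, it remains open whether an amine, a carboxylic acid or a fluoro group at this same place would shift the number beyond the scatter. As far as these compounds go, it is also open whether removing a bromo has an equally small effect on other cores, since this single pair speaks only for the core of compound 1.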